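Moving the Nitrile Group on the Amide Ring

This account rests on a few compounds, and the source may have more. Where it says the series, first, only, none or still open, it means among the compounds named here.

Three measured compounds share one core and differ only in the ring joined to the amide carbonyl. Compound 1 `Cn1c(-c2cccc(Cl)c2)cnc1NC(=O)c1ccc(F)cc1` carries a fluorine-bearing ring, compound 2 `COc1ccc(-c2cnc(NC(=O)c3cccc([N+](=O)[O-])c3)n2C)cc1` a nitro-bearing ring and compound 3 `COc1ccc(-c2cnc(NC(=O)c3cccc(C#N)c3)n2C)cc1` a cyano-bearing ring. In a toxicity assay on THP-1 cells (Homo sapiens) for inhibition (on this read-out lower numbers stand for higher toxicity in this test and higher numbers for lower toxicity in this test), compound 1 gives > 50000 nM, which is a limit of the assay and not a number. In this assay compound 2 gives > 100000 nM, again a limit. In this assay compound 3 gives > 100000 nM, also a limit. The step that the two limits leave unreadable from compound 2 to compound 3 has no readable size. Compound 3 stands at a limit, and the other two values are limits as well: the limit of > 100000 nM in this assay, at which 2 of the 3 values shown sit, and (the limit of > 50000 nM in this assay, at which 1 of the 3 values shown sits).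

Compound 4 `COc1ccc(-c2cnc(NC(=O)c3ccccc3C#N)n2C)cc1` is the unmeasured partner. The change is 2-cyanophenyl in place of 3-cyanophenyl on a carbonyl carbon. Among the measured compounds shown here, the only measured step bearing on it, a step that the two limits leave unreadable from compound 2 to compound 3, is unreadable, and every value so far sits at a limit, so no step beyond the scatter is expected in this assay. Compound 4 is expected to give 100000 nM in this assay, with a range from 40000 nM to 250000 nM. The expected step of a number no higher from compound 3 to compound 4 (the limit leaves the size open) is essentially none, most likely another limit.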

Compound 4, half-maximal cytotoxic concentration: > 100000 nM
Compound 4: no number, only a limit; the forecaster's own chance of this, stated with the estimate: 85%; the middle value sits exactly at the limit.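

In this assay compound 3 and compound 4 both give only limits of the assay, not numbers, so no step can be read between them. The compounds shown leave open whether 2-cyanophenyl and 3-cyanophenyl differ in toxicity at all: the limit of > 100000 nM in this assay, at which 3 of the 4 values shown sit.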